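A few compounds are considered here, and "the series" means these few. Any claim that something is new, unique, unknown or untested is made for them only; others in the source may bear on it.

Measured compounds:
compound 1, `COc1ccccc1/C=c1/[nH]c(=O)/c(=C\c2ccccc2OC)[nH]c1=O`: "not active" (no number reported)
compound 2, `COc1ccccc1/C=c1\c(=O)[nH]/c(=C/c2cccc(Cl)c2Cl)c(=O)n1C`: 300 nM
compound 3, `C=CCn1c(=O)/c(=C\c2ccc(Cl)c(Cl)c2)[nH]c(=O)/c1=C\c1ccccc1`: "not active" (no number reported)

In a functional assay on Huh-7 cells (Homo sapiens) for cytotoxicity, read by CCK-8 assay, with a stated time of 72 h (on this read-out higher numbers stand for weaker inhibition and lower numbers for stronger inhibition), compound 1 gives "not active" (no number reported), so no single number is on record for it. Compound 3 also gives "not active" (no number reported) in this assay, and only compound 2 returns a number, 300 nM. Compound 1 therefore stands among the two entries without a figure, and nothing about its own step to compound 2 or compound 3 can be read from the data, since those pairs differ in more than one place.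

Compound 4, `C=CCn1c(=O)/c(=C\c2ccccc2OC)[nH]c(=O)/c1=C\c1ccccc1OC`, differs from compound 1 by allyl in place of hydrogen on an aromatic nitrogen. For the measured compounds named here, with no measured step of this kind available, the expectation rests on the fact that compound 3, which carries an allyl on the same kind of aromatic nitrogen, is not active, while the one active entry, compound 2, owes its number to a different structural setting. He expects the step from compound 1 to compound 4 in this assay to bring, at most, a modest move toward stronger inhibition, and more likely none beyond the scatter, with a real chance that compound 4 is again reported without a number. For compound 4 his estimate in this assay is 15000 nM, within the range 3000 nM to 60000 nM.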

Compound 4, half-maximal inhibitory concentration: 21200 nM
Compound 4: the middle estimate sits 1.4-fold (0.15 log units) below what was measured, and the stated range covers the measured number.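

For the compounds shown here, compound 1 gives "not active" (no number reported) in this assay while compound 4 gives 21200 nM there, and no step from compound 1 to compound 4 can be read from this pair. Nothing at hand accounts for the result. The compounds shown leave open what allyl in place of hydrogen on the aromatic nitrogen does to inhibition in this assay.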